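The source may report more compounds than this note shows. Statements on the series, on what has been measured and on what is new or still open speak of the compounds shown alone.

Measured compounds:
Compound 1, `C=CC(=O)O[C@@H](Cc1ccccc1)CN1CCN(CCCN(c2ccc(F)cc2)c2ccc(F)cc2)CC1`, gives 3.26 nM in an assay on membranes from striatum for displacement of a labelled ligand from sodium-dependent dopamine transporter (Rattus norvegicus); a lower number here means a stronger inhibitor, a higher number a weaker inhibitor.
Compound 2, `CC(=O)OC(CCN1CCN(CCCN(c2ccc(F)cc2)c2ccc(F)cc2)CC1)c1ccccc1`, gives 4.28 nM in this assay.

Compound 2 carries the higher of the two numbers, but its nearest neighbour is compound 1, and the gap between the two values lies within the usual scatter, so the two compounds cannot be told apart on these data. Compound 3, `O[C@@H](Cc1ccccc1)CN1CCN(CCCN(c2ccc(F)cc2)c2ccc(F)cc2)CC1`, has not yet been measured. It differs from compound 2 in one place: 1-hydroxy-2-phenylethyl in place of 2-acetoxy-2-phenylethyl on a saturated chain carbon bound to an amine nitrogen in a ring. Among the measured compounds shown here, no step between measured compounds covers a change of this kind, so the expectation rests on the two values alone. Compound 3 is expected to give a slightly higher number than compound 2, a step of roughly a 1.9-fold higher number from compound 2 to compound 3 (0.27 log units; within the scatter), close to the edge of the scatter. Compound 3 is estimated at 8 nM, in the range 3 nM to 25 nM.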

Compound 3, inhibition constant: 1.72 nM
Beside the measured number, compound 3's estimate is 4.7-fold (0.67 log units) above it; measured number below the stated range.
By their numbers in this assay, from the lowest: compounds 3, 1 and 2 (each within the scatter of the next, the first and the last beyond it).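

In this assay, the change on a saturated chain carbon bound to an amine nitrogen in a ring, 1-hydroxy-2-phenylethyl in place of 2-acetoxy-2-phenylethyl, gives a 2.5-fold lower number from compound 2 to compound 3 (0.40 log units; beyond the scatter), so the ester-bearing group is not needed for a low number at this position. Hydrogen in place of vinylcarbonyl on an oxygen on a saturated carbon gives a 1.9-fold lower number from compound 1 to compound 3 (0.28 log units; within the scatter), which leaves these two compounds indistinguishable, and the free hydroxy group therefore serves at least as well here as the acylated oxygen of compound 1. Nothing measured alongside these values explains either step.

The compounds shown leave open whether a methoxy group or an amine in place of the hydroxy group would keep the number this low. They also leave open whether the mirror-image arrangement at the defined stereocentre of 1-hydroxy-2-phenylethyl would do the same.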